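Two compounds and one stereocentre in the series

This account rests on a few compounds, and the source may have more. Where it says the series, first, only, none or still open, it means among the compounds named here.

Measured in a functional assay on MDA-MB-231 cells (Homo sapiens) for cytotoxicity, read by sulforhodamine B assay; a lower number here means a stronger inhibitor of growth, a higher number a weaker inhibitor of growth:
- compound 1 `O=C(NCCCCCNC(=O)C1=NO[C@]2(C=C(Br)C(=O)[C@@H](Br)[C@@H]2O)C1)C1=NO[C@]2(C=C(Br)C(=O)[C@@H](Br)[C@@H]2O)C1`: 2100 nM
- compound 2 `COC1=C(Br)[C@H](O)[C@@]2(C=C1Br)CC(C(=O)NCCCCNC(=O)C1=NO[C@]3(C=C(Br)C(=O)[C@@H](Br)[C@@H]3O)C1)=NO2`: 5000 nM

Compound 2 holds the higher of the two numbers, at 5000 nM, which makes it the weaker growth inhibitor of the pair. Its gap to compound 1 lies beyond the usual scatter. These two compounds differ in more than one place, so their gap gives no direct measure of a single stereochemical change.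

Next in line is compound 3 `COC1=C(Br)[C@H](O)[C@@]2(C=C1Br)CC(C(=O)NCCCCNC(=O)C1=NO[C@]3(C=C(Br)C(=O)[C@H](Br)[C@@H]3O)C1)=NO2`. The change is the two compounds have the same atoms and bonds and differ only in configuration as drawn: 1 of 5 stereo elements differ; a stereocentre at a saturated ring carbon is drawn S in compound 2 and R in compound 3. Among the measured compounds shown here, no measured pair isolates a change of this kind, so the data offer no direct precedent. With nothing to set a direction, the expectation stays anchored on compound 2 at 5000 nM. In this assay the expected move is a 1.1-fold higher number from compound 2 to compound 3 (0.04 log units; within the scatter), and it is not expected to exceed the scatter. The range is kept wide to allow for a real effect of configuration in either direction. For compound 3 the estimated value is 5500 nM, with an expected range of 2300 nM to 12000 nM.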

Compound 3, concentration for total growth inhibition: 4700 nM
Compound 3: the middle estimate sits 1.2-fold (0.07 log units) above what was measured; the range from low to high includes it.
By their numbers in this assay, from the lowest: compound 1; then compounds 3 and 2 (each within the scatter of the next).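

In this assay, the inversion of the stereocentre at the saturated ring carbon, drawn S in compound 2 and R in compound 3, gives a 1.1-fold lower number from compound 2 to compound 3 (0.03 log units; within the scatter). Among the compounds shown here, this is the first pair that isolates a single change, so the step can be read as a direct measure of configuration at this position, and the reading rests on one fact: the fact that compounds 2 and 3 differ only in the configuration as drawn. At this position and with the rest of the structure held as in compound 2 and compound 3, growth inhibition does not separate the two drawn configurations beyond the scatter, although this one pair says nothing about the other stereo elements.

On these data alone, compound 1, at 2100 nM, differs from this pair in more than one place, so its value cannot be assigned to any single feature, and whether the same inversion would read the same way in its structure remains open. Also open, as far as these compounds go, is how a longer chain joining the two ends of the molecule, or an amine at that saturated ring carbon, would read in this assay.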